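The compounds below may be only part of what the source reports. "The series", "measured", "known", "first", "only" and "open" are said of these compounds alone.

The measured compounds are compound 1, `CC/C=C\C(=O)Nc1cc(Nc2nc3c(c(-c4cn(C)c5ccc(F)cc45)n2)CSCC3)c(OC)cc1N(C)CCN(C)C`, which in a functional assay on A549 cells (Homo sapiens) for inhibition, read by MTT assay, with a stated time of 72 h (a higher number here means a weaker inhibitor, a lower number a stronger inhibitor), gives 1450 nM; compound 2, `CCC/C=C\C(=O)Nc1cc(Nc2nc3c(c(-c4cn(C)c5ccc(F)cc45)n2)CSCC3)c(OC)cc1N(C)CCN(C)C`, which in this assay gives 5190 nM; and compound 3, `C/C=C\C(=O)Nc1cc(Nc2nc3c(c(-c4cn(C)c5ccccc45)n2)CSCC3)c(OC)cc1N(C)CCN(C)C`, which in this assay gives 6860 nM.

Between compound 1 and compound 2 the change is methyl in place of hydrogen on a saturated chain carbon, two bonds along the chain from a double-bonded chain carbon, and it gave a 3.6-fold higher number from compound 1 to compound 2 (0.55 log units; beyond the scatter). Compound 3 stands furthest from compound 1, while its value and that of compound 2 lie within the scatter of each other. How the core of compound 3 differs from that of compound 1 is not broken down here.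

Compound 4, `CC/C=C\C(=O)Nc1cc(Nc2nc3c(c(-c4cn(C)c5ccccc45)n2)CSCC3)c(OC)cc1N(C)CCN(C)C`, has not yet been measured. It differs from compound 3 by methyl in place of hydrogen on a saturated chain carbon bound to a double-bonded chain carbon. Within the data shown here, this is the same kind of change as the one from compound 1 to compound 2, but the place differs: there the methyl enters two bonds along the chain from the double-bonded chain carbon, here on a saturated chain carbon bound to it. Because a 3.6-fold higher number from compound 1 to compound 2 (0.55 log units; beyond the scatter) weakened inhibition, a weakening of similar direction but uncertain size is expected for compound 4, namely a 1.4-fold higher number from compound 3 to compound 4 (0.14 log units; within the scatter). Compound 4 is therefore estimated at 9500 nM, between 3000 nM and 30000 nM, in this assay.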

Compound 4, half-maximal inhibitory concentration: 236 nM
Estimate against measurement, compound 4: 40-fold (1.60 log units) above; the measured number lies below the stated range.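

In this assay, the added methyl did not carry over from one core to the other, and the two steps run in opposite directions: the same change on two cores in this assay, a 3.6-fold higher number (0.55 log units; beyond the scatter) from compound 1 to compound 2 and a 29-fold lower number (1.46 log units; beyond the scatter) from compound 3 to compound 4, 100-fold (2.02 log units) apart, beyond the scatter of two such steps. On the core without fluoro, methyl in place of hydrogen gave a 29-fold lower number from compound 3 to compound 4 (1.46 log units; beyond the scatter), while with the but-1-en-1-yl chain held constant, hydrogen in place of fluoro on an aromatic carbon gave a 6.1-fold lower number from compound 1 to compound 4 (0.79 log units; beyond the scatter). The two methyl steps differ both in the core and in the place where the methyl enters, and these compounds do not separate the two, so it remains unshown whether the core alone reverses the effect.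

From the compounds shown here alone, what the prop-1-en-1-yl chain gives on the core of compound 1 remains open, and so does what a chain longer than but-1-en-1-yl gives on the core of compound 4. Also open, going by these compounds, is how a chloro group in place of the fluoro, or an amine at the end of the chain, would read in this assay.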